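Working notes: tert-butoxycarbonyl to acetyl on the nitrogen

A few compounds are considered here, and "the series" means these few. Any claim that something is new, unique, unknown or untested is made for them only; others in the source may bear on it.

Measured so far in an assay on isolated protein for inhibition of cytochrome c oxidase subunit 2 (Homo sapiens), read by ELISA, with a stated time of 2 min, tested at 10 uM; a higher number here means more inhibition at the concentration tested (going by the name of the read-out), a lower number less inhibition:
Compound 1 `O=C1C=C(Nc2ccc(Cl)cc2)CCC1`: 88.6%
Compound 2 `O=C1C=C(NCc2ccco2)CC1`: 41.4%
Compound 3 `CC(C)(C)OC(=O)N(C1=CC(=O)CCC1)c1ccc(Cl)cc1`: 73.5%

Compound 3 stands second of the three numbers in this assay, beyond the scatter from compound 1 above it and from compound 2 below it. Among the compounds with values here, the only step measured in one place is a number 15.1 percentage points lower from compound 1 to compound 3 (beyond the scatter), tert-butoxycarbonyl in place of hydrogen on a nitrogen on an aromatic ring. Compound 4 `CC(=O)N(C1=CC(=O)CCC1)c1ccc(Cl)cc1` differs from compound 3 by methyl in place of tert-butoxy on a carbonyl carbon; the same difference, cut one bond further out, reads tert-butoxycarbonyl to acetyl. Within the data shown here, no measured step compares one acyl group with another on this nitrogen; the step to compound 3 bears on it only by marking the distance between acylated and unsubstituted nitrogen. A step of a number 3.5 percentage points higher from compound 3 to compound 4 (within the scatter) is expected, within or near the scatter. For compound 4 the estimate in this assay is 77%, with a range from 60% to 90%.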

Compound 4, a percentage reported as inhibition, at one concentration (the size of the read-out at that concentration, not a potency): 96.9%
For compound 4 the middle estimate is 19.9 percentage points below the measured one, and the stated range ends below it.
By their numbers in this assay, from the lowest: compound 2; then compound 3; then compounds 1 and 4 (each within the scatter of the next).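

On this nitrogen the acyl groups are not interchangeable in this assay: methyl in place of tert-butoxy on the carbonyl carbon gives a clear change (a number 23.4 percentage points higher from compound 3 to compound 4 (beyond the scatter)). Acetyl on the nitrogen stays level with the unsubstituted nitrogen (a number 8.3 percentage points higher from compound 1 to compound 4 (within the scatter)), so the lower number of compound 3 goes with tert-butoxycarbonyl and not with acylation of this nitrogen as such. No measured evidence accounts for this difference between the two acyl groups.

Open, on these data alone, is how benzoyl, methanesulfonyl or plain methyl on this nitrogen would read. Also open, as far as these compounds go, is whether the acetyl result holds with methoxy in place of the chlorine on the aromatic ring.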